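An Amide-to-Urea Change in a Weakly Active Series

A few compounds are considered here, and "the series" means these few. Any claim that something is new, unique, unknown or untested is made for them only; others in the source may bear on it.

Compound 1 `O=C(c1ccccc1F)N1CC[C@H]1c1nc(-c2cccc(F)c2)no1`: > 10000 nM
Compound 2 `O=C(c1ccc(F)cc1)N1CC(c2nc(-c3cccc(Cl)c3)no2)C1`: > 10000 nM

The read-out is an assay on HEK293 cells for positive allosteric modulation of metabotropic glutamate receptor 5 (Homo sapiens), read by FLIPR; a higher number here means that more compound is needed for the effect, a lower number that less compound is needed. Compound 2 gives > 10000 nM in this assay, and that figure is a limit of the assay rather than a number. Compound 1 likewise gives > 10000 nM, again only a limit. Where compound 2 stands is therefore set by the limit of > 10000 nM in this assay, at which 2 of the 2 values shown sit: it shares the limit with the only other compound shown, and no measured step between the two exists, so nothing can be said about the size of any difference between them.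

Compound 3 `COC1CCN(C(=O)N2CC(c3nc(-c4cccc(Cl)c4)no3)C2)CC1` differs from compound 2 in one place: 4-methoxypiperidin-1-yl in place of 4-fluorophenyl on a carbonyl carbon. With both shown values at the limit and no measured step to draw on, the step from compound 2 to compound 3 is expected to be a number no higher from compound 2 to compound 3 (the limit leaves the size open), that is, nothing beyond the scatter. Compound 3 is accordingly estimated at 10000 nM, within a range from 3000 nM to 30000 nM, and it is expected most likely to be reported as a limit once more.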

Compound 3, half-maximal effective concentration: > 10000 nM
Compound 3 was reported as a limit (the forecaster's own chance of this, stated with the estimate: 75%); the middle value lies on the limit itself.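

Compound 3 gives > 10000 nM in this assay and this is a limit, not a number. No step from compound 2 to compound 3 can be read, and the three compounds shown stand together: the limit of > 10000 nM in this assay, at which 3 of the 3 values shown sit. Going by these compounds, what stays open is how far each compound lies from that limit, and whether 4-methoxypiperidin-1-yl in place of 4-fluorophenyl changes the read-out at all.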